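A few compounds are considered here, and "the series" means these few. Any claim that something is new, unique, unknown or untested is made for them only; others in the source may bear on it.

In an ADME assay on microsomes from liver (Mus musculus) for metabolic stability (a higher number here means faster removal of the compound, a lower number slower removal), compound 1 `CC(C(=O)O)c1nn(Cc2cn3cc(OCC4CC4)c(Cl)cc3n2)c2ccccc2c1=O` gives 80 mL/min/kg. Compound 2 `O=C(O)C1(c2nn(Cc3cn4cc(OCC5CC5)c(Cl)cc4n3)c3ccccc3c2=O)CC1` reads < 53.4 mL/min/kg, which is a limit of the assay and not a number. The change to compound 3 `CCC(C(=O)O)c1nn(Cc2cn3cc(OCC4CC4)c(Cl)cc3n2)c2ccccc2c1=O` is 1-carboxypropyl in place of 1-carboxycyclopropyl on an aromatic carbon. Among the compounds with values here, only one measured step bears on it, an at least 1.4-fold lower number from compound 1 to compound 2 (0.17 log units; that floor lies within the scatter), and that floor stays within the scatter. The entering group has no ring, like the 1-carboxyethyl of compound 1 at 80 mL/min/kg, so a move back toward a higher number in this assay is expected. The expected step is an at least 1.4-fold higher number from compound 2 to compound 3 (0.17 log units; that floor lies within the scatter). Compound 3 is estimated at 80 mL/min/kg, with a range from 45 mL/min/kg to 140 mL/min/kg.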

Compound 3, clearance: < 56.7 mL/min/kg
Compound 3 gave a limit, no number; the forecaster's own chance of this, stated with the estimate: 15%; middle value at least 1.4-fold (0.14 log units) from the limit.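

In this assay, methyl in place of hydrogen on a saturated chain carbon gives an at least 1.4-fold lower number from compound 1 to compound 3 (0.14 log units; that floor lies within the scatter) and so does not separate the two compounds beyond the scatter. Still, the 1-carboxypropyl of compound 3, which has no ring, ends in a limit of the assay, just as the 1-carboxycyclopropyl of compound 2 does, so a limit at this position does not depend on the three-membered ring. With only limits on both sides, the step between these two cannot be read. Going by these compounds, how far the true values lie beneath those limits stays open, as does whether a 1-carboxybutyl chain, or an amide in place of the carboxylic acid, would also read as a limit.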